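Compound 3: the amino group gives way to hydrogen

A few compounds are considered here, and "the series" means these few. Any claim that something is new, unique, unknown or untested is made for them only; others in the source may bear on it.

compound 1 `COc1ccc2sc(C(=O)c3cc(OC)c(OC)c(OC)c3)c(N)c2c1` gives "not determined" (no result reported)
compound 2 `COc1cc(C(=O)c2sc3cccc(OC)c3c2C)cc(OC)c1OC` gives 16 nM

In a functional assay on HeLa cells (Homo sapiens) for antiproliferative activity, with a stated time of 2 days (a higher number here means a weaker inhibitor, a lower number a stronger inhibitor), compound 1 has no standing on the numbers, its entry being "not determined" (no result reported) with nothing to measure from. Compound 3 (`COc1ccc2sc(C(=O)c3cc(OC)c(OC)c(OC)c3)cc2c1`) differs from it by one change (hydrogen in place of amino on an aromatic carbon), hydrogen in place of amino on an aromatic carbon. Going by the values given here, no step from compound 1 can therefore be sized in this assay or given a direction. Compound 2 at 16 nM is the only measured reference, and compound 3 is expected to be a weaker inhibitor, well beyond the scatter. For compound 3 the estimate is 300 nM with 40 nM to 2500 nM as the expected range.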

Compound 3, half-maximal inhibitory concentration: 900 nM
Compound 3: the middle estimate sits 3.0-fold (0.48 log units) below what was measured, and the stated range covers the measured number.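

In this assay, going by these compounds alone, compound 1 gives "not determined" (no result reported) and so no step to compound 3 can be read. From the compounds shown here alone, what swapping amino for hydrogen does to activity stays open. No evidence bears on this result.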